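Side-chain amine series: from propyl to ester

The source may hold more compounds than are shown below. What is called first, only, known or untested is meant among the compounds shown, and "the series" means these compounds.

In a functional assay on SK-BR-3 cells (Homo sapiens) for antiproliferative activity (on this read-out lower numbers stand for stronger inhibition and higher numbers for weaker inhibition), compound 1 `CC(C)=CCc1cc(C(=O)Nc2cc3ccc(OCC4CCCN(C)C4)c(C)c3oc2=O)ccc1O` gives 1300 nM and compound 2 `CCCNCCCOc1ccc2cc(NC(=O)c3ccc(O)c(CC=C(C)C)c3)c(=O)oc2c1C` gives 990 nM. Compound 2 therefore sits within the scatter of compound 1, the only other measured point, and the two read as level.

The next point is compound 3 `COC(=O)CNCCCOc1ccc2cc(NC(=O)c3ccc(O)c(CC=C(C)C)c3)c(=O)oc2c1C`, still unmeasured. It carries methoxycarbonyl in place of ethyl on a saturated chain carbon bound to an amine nitrogen. Cut one bond further out, this reads propyl to (methoxycarbonyl)methyl.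

Within the data shown here, only one measured step bears on this change: a 1.3-fold lower number from compound 1 to compound 2 (0.12 log units; within the scatter). That replacement lies on a saturated chain carbon bound to an oxygen on an aromatic ring, and it stays within the scatter. Among the measured compounds shown here, no measured compound carries methoxycarbonyl, so the data give no direct reading for this group, and a single step sets no firm direction.

No shift beyond the scatter is therefore expected in this assay, and the estimated step is a 1.2-fold higher number from compound 2 to compound 3 (0.08 log units; within the scatter). For compound 3 the expected value is 1200 nM, with an estimated range of 450 nM to 3200 nM.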

Compound 3, half-maximal inhibitory concentration: 1060 nM
Compound 3: the middle estimate sits 1.1-fold (0.05 log units) above what was measured; the measured number falls inside the stated range.
By their numbers in this assay, from the lowest: compounds 2, 3 and 1 (each within the scatter of the next).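

Among these compounds, this is the first measured change made on the amine substituent itself: in this assay, methoxycarbonyl in place of ethyl on a saturated chain carbon bound to an amine nitrogen gives a 1.1-fold higher number from compound 2 to compound 3 (0.03 log units; within the scatter). The read-out therefore shows no shift beyond the scatter on moving from a plain alkyl end to an ester end, even though methoxycarbonyl brings more heavy atoms and hydrogen-bond acceptors than ethyl. The longer-range comparison agrees, with a 1.2-fold lower number from compound 1 to compound 3 (0.09 log units; within the scatter), so the three compounds remain level in this assay and nothing in hand accounts for that flatness.

On these data alone, it remains open whether any replacement at this position can move the number beyond the scatter, for example a carboxylic acid in place of the methoxycarbonyl, a longer chain on the amine nitrogen, or a second alkyl group that makes it a tertiary amine. As far as these compounds go, with the shared core held fixed in these compounds, it is also open whether this tolerance would persist alongside a change elsewhere in the molecule.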